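Inverting One Ring Stereocentre: From Compound 2 to Compound 4

A few compounds are considered here, and "the series" means these few. Any claim that something is new, unique, unknown or untested is made for them only; others in the source may bear on it.

Compound 1 `C=C1CCCC(C)(C)C1CC[C@]1(C)CC[C@H]([C@@H](C)C(=O)OC)OO1` gives 380 nM.
Compound 2 `C=C1CCC[C@H]2[C@](C)(CC[C@]3(C)CC[C@@H]([C@@H](C)C(=O)O)OO3)[C@@H](C)CC[C@]12C` gives 1030 nM.
Compound 3 `CC1=C(CC/C(C)=C/CC[C@@]2(C)CC[C@@H]([C@H](C)C(=O)O)OO2)C(C)(C)CCC1` gives > 100000 nM.

In a functional assay on HT-29 cells (Homo sapiens) for inhibition (on this read-out higher numbers stand for weaker inhibition of growth and lower numbers for stronger inhibition of growth), compound 2 stands at the higher of the two numbers recorded; compound 1 gives a lower number, and the gap between them lies beyond the scatter. For compound 3 this assay reports only a limit, which is not a number. Going by the values given here, compound 4 `C=C1CCC[C@H]2[C@](C)(CC[C@]3(C)CC[C@H]([C@@H](C)C(=O)O)OO3)[C@@H](C)CC[C@]12C` has not been measured. the two compounds have the same atoms and bonds and differ only in configuration as drawn: 1 of 7 stereo elements differ; a stereocentre at a saturated ring carbon is drawn S in compound 2 and R in compound 4 No measured pair here shows what such an inversion does. A step of modest size in this assay is expected, more likely towards a higher number, though one within the scatter cannot be ruled out. Compound 4 is expected to give about 2000 nM, between 300 nM and 15000 nM. The expected step from compound 2 to compound 4 is a 1.9-fold higher number from compound 2 to compound 4 (0.29 log units; within the scatter).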

Compound 4, concentration for 50% growth inhibition: 1570 nM
Compound 4: middle estimate off by 1.3-fold (0.11 log units), on the high side; the range from low to high includes it.
By their numbers in this assay, from the lowest: compound 1; then compounds 2 and 4 (each within the scatter of the next). At a limit, above all of these: compound 3.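

In this assay, inverting the stereocentre at a saturated ring carbon from S to R is a step of a 1.5-fold higher number from compound 2 to compound 4 (0.18 log units; within the scatter), so the two configurations at this carbon cannot be told apart on this read-out. This is the first measured inversion in the series, and the comparison isolates configuration alone: the fact that compounds 2 and 4 differ only in the configuration as drawn

Going by these compounds, whether inverting any of the other stereo elements would be equally silent remains open. So does whether the two configurations would still match with an amide in place of the carboxylic acid.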